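The source may hold more compounds than are shown below. What is called first, only, known or untested is meant among the compounds shown, and "the series" means these compounds.

In a functional assay on KB cells (Homo sapiens) for inhibition (a higher number here means a weaker inhibitor, a lower number a stronger inhibitor), compound 1 (`COC[C@H]1O[C@@H](n2c(Cl)nc3cc(Cl)c(Cl)cc32)[C@H](OC(C)=O)[C@@H]1OC(C)=O`) gives 80000 nM and compound 2 (`CC(=O)OC1C(CF)OC(n2c(Cl)nc3cc(Cl)c(Cl)cc32)C1OC(C)=O`) gives 100000 nM, two values that lie within the usual scatter of each other. Compound 3 (`CC(=O)OC1C(CN=[N+]=[N-])OC(n2c(Cl)nc3cc(Cl)c(Cl)cc32)C1OC(C)=O`) differs from compound 2 in one place, with azido in place of fluoro on a saturated chain carbon bound to a saturated ring carbon. Among the measured compounds shown here, no measured pair shows this swap, so no step beyond the scatter is expected in this assay. The estimated step of a 1.4-fold lower number from compound 2 to compound 3 (0.15 log units; within the scatter) is small, with no firm direction. For compound 3, the expected value is 70000 nM, within an estimated range of 25000 nM to 150000 nM.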

Compound 3, half-maximal inhibitory concentration: 70000 nM
Beside the measured number, compound 3's estimate shows no gap at the digits printed, within the range that was stated.
By their numbers in this assay, from the lowest: compounds 3, 1 and 2 (each within the scatter of the next).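

In this assay, replacing fluoromethyl with azidomethyl gives a 1.4-fold lower number from compound 2 to compound 3 (0.15 log units; within the scatter). On this saturated chain carbon bound to a saturated ring carbon, a group of 3 heavy atoms can therefore stand in place of a group of 1 heavy atom with no step beyond the scatter. Among the compounds shown here, this is the first direct reading of a change at this position, and it gives the swap no firm direction.

Going by these compounds, whether an amine or a carboxylic acid at the same place would read differently remains open. No measurement shown gives any reason for this result.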